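A few compounds are considered here, and "the series" means these few. Any claim that something is new, unique, unknown or untested is made for them only; others in the source may bear on it.

Of the compounds shown here, three of a shared core have been measured in an assay on HEK293 cells for displacement of a labelled ligand from Melanocortin receptor 4 (Homo sapiens); on this read-out lower numbers stand for stronger inhibition and higher numbers for weaker inhibition. Compound 1 `CCC(C)[C@H](N)c1cc(C(F)(F)F)ccc1N1CCN(C(=O)CCc2ccc(OC)cc2Cl)CC1` gives 57 nM, compound 2 `Cc1cccc(CCC(=O)N2CCN(c3ccc(C(F)(F)F)cc3[C@@H](N)CC(C)C)CC2)c1` gives 2100 nM, and compound 3 `CCN[C@H](c1cc(C(F)(F)F)ccc1N1CCN(C(=O)CCc2ccc(Cl)cc2Cl)CC1)C(C)CC` gives 92 nM. Compound 3 thus stands second highest of the three numbers; its nearest neighbour is compound 1, whose number lies within the usual scatter of compound 3, so no order between these two can be read, while compound 2 lies furthest away with a number well beyond the scatter. Going by the values given here, no single-point step between measured compounds is available, so the effect of any one change must be inferred.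

Compound 4 `CC(C)C[C@H](NC(=O)CN)c1cc(C(F)(F)F)ccc1N1CCN(C(=O)CCc2ccc(Cl)cc2Cl)CC1` has not yet been measured in this assay. It differs from compound 3 as follows: 1-(((aminomethyl)carbonyl)amino)-3-methylbutyl in place of 1-(ethylamino)-2-methylbutyl on an aromatic carbon. The group that enters carries an amide and a further amine where compound 3 carries a simple secondary amine, and the branching of the chain shifts as well, so more than one thing moves at once.

Without a measured step that isolates such a change, the account expects the number in this assay to rise by a moderate step, a 3.3-fold higher number from compound 3 to compound 4 (0.51 log units; beyond the scatter), but with wide uncertainty in either direction. Compound 4 is estimated at 300 nM, within a range from 50 nM to 2000 nM.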

Compound 4, inhibition constant: 19 nM
The estimate for compound 4 lay 16-fold (1.20 log units) above the measured number, outside the stated range (below it).
By their numbers in this assay, from the lowest: compound 4; then compounds 1 and 3 (each within the scatter of the next); then compound 2.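

Going by these compounds alone, with this step, the position on an aromatic carbon, ortho to a large group and meta to a trifluoromethyl group, is seen for the first time to respond to a change made there alone: in this assay, putting 1-(((aminomethyl)carbonyl)amino)-3-methylbutyl in place of 1-(ethylamino)-2-methylbutyl gives a 4.8-fold lower number from compound 3 to compound 4 (0.69 log units; beyond the scatter). The position therefore accepts a larger group carrying an amide and a further amine, with no loss in this read-out and a modest gain instead. No measurement here bears on why the number falls.

The amide, the further amine and the shift in the branching of the chain all move together in this one step, so the compounds shown do not separate what each contributes. They also leave open how this position would respond to a plain acetamide without the further amine, to a dimethylamine in place of that amine, or to a longer chain carrying it.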